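Swapping the anilino aryl group on a shared nitrile core

This account rests on a few compounds, and the source may have more. Where it says the series, first, only, none or still open, it means among the compounds named here.

Compound 1 `CC(C)c1ccc(-c2nc(SCc3cn(CC(=O)NC(=O)Nc4ccccn4)nn3)nc(Nc3cccc(Cl)c3)c2C#N)cc1` gives 13300 nM in a functional assay on ECa-109 cells (Homo sapiens) for inhibition, read by MTT assay, with a stated time of 72 h; on this read-out higher numbers stand for weaker inhibition and lower numbers for stronger inhibition. Compound 2 `COc1ccc(Nc2nc(SCc3cn(CC(=O)NC(=O)Nc4ccccn4)nn3)nc(-c3ccc(C)cc3)c2C#N)cc1` gives 5870 nM. Compound 3 `Cc1ccc(Nc2nc(SCc3cn(CC(=O)NC(=O)Nc4ccccn4)nn3)nc(-c3ccc(C)cc3)c2C#N)cc1` gives > 64000 nM, which is a limit of the assay and not a number (the limit of > 64000 nM in this assay, at which 1 of the 3 values shown sits).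

Compound 3 therefore stands at the weak end of what is shown. The step to compound 4 `Cc1ccc(-c2nc(SCc3cn(CC(=O)NC(=O)Nc4ccccn4)nn3)nc(Nc3cccc(Cl)c3)c2C#N)cc1` is 3-chlorophenyl in place of 4-methylphenyl on a nitrogen on an aromatic ring. Among the measured compounds shown here, no measured step covers this exact change; the closest, an at least 10-fold higher number from compound 2 to compound 3 (1.03 log units; beyond the scatter), shows that altering this ring can move the read-out strongly. Compound 1, which carries the same 3-chlorophenyl group, gives 13300 nM. Compound 4 is therefore expected to show a lower number than the limit of compound 3, with the step estimated as an at least 4.2-fold lower number from compound 3 to compound 4 (0.63 log units; beyond the scatter). The estimate for compound 4 is 15000 nM, in the range 4000 nM to 60000 nM.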

Compound 4, half-maximal inhibitory concentration: 25600 nM
Estimate against measurement, compound 4: 1.7-fold (0.23 log units) below; the range from low to high includes it.
By their numbers in this assay, from the lowest: compound 2; then compounds 1 and 4 (each within the scatter of the next). At a limit, above all of these: compound 3.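

Among compound 2, compound 3 and compound 4, which differ only on this nitrogen, 3-chlorophenyl improves on 4-methylphenyl, with an at least 2.5-fold lower number from compound 3 to compound 4 (0.39 log units; beyond the scatter), but falls short of 4-methoxyphenyl, with a 4.4-fold higher number from compound 2 to compound 4 (0.64 log units; beyond the scatter). The value of compound 3 remains a limit of the assay and not a number: the limit of > 64000 nM in this assay, at which 1 of the 4 values shown sits. With 3-chlorophenyl kept, methyl in place of isopropyl on an aromatic carbon gives a 1.9-fold higher number from compound 1 to compound 4 (0.28 log units; within the scatter), so this change does not separate the two compounds.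

The compounds shown leave open how a plain phenyl, or an amine or hydroxyl group on this phenyl ring, would compare.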